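This account rests on a few compounds, and the source may have more. Where it says the series, first, only, none or still open, it means among the compounds named here.

Measured in a functional assay on SH-SY5Y cells (Homo sapiens) for antiproliferative activity, read by MTT assay, with a stated time of 48 h; a lower number here means a stronger inhibitor of growth, a higher number a weaker inhibitor of growth:

compound 1 `COc1ccc(N(C)c2nc(Cl)nc3c2ncn3Cc2ccc(OC)c(OC)c2)cc1`: 7300 nM
compound 2 `COc1ccc(Cn2cnc3c(Cl)ncnc32)cc1OC`: > 100000 nM (a limit)
compound 3 `COc1cc(Cn2cnc3c(Cl)ncnc32)cc(OC)c1OC`: > 100000 nM (a limit)

Compound 2 stands at a limit and not at a number: > 100000 nM. Compound 3 is likewise reported only as a limit: > 100000 nM. Together they make up (the limit of > 100000 nM in this assay, at which 2 of the 3 values shown sit).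

Compound 4 `COc1ccc(Cn2cnc3c(Cl)nc(Cl)nc32)cc1OC` departs from compound 2 in one place: chloro in place of hydrogen on an aromatic carbon. This puts a chloro in place of hydrogen on an aromatic carbon, between two ring nitrogen atoms.

Going by the values given here, the only measured single-place change is a step that the two limits leave unreadable from compound 2 to compound 3, so no measured size carries over to the new chloro. Among the compounds with values here, the one number available comes from compound 1 , which also has a chloro on that carbon and gives 7300 nM. However, compound 1 differs from compound 4 in other places as well, so it offers only a weak hint.

A shift towards stronger growth inhibition is therefore expected, though it may be modest and compound 4 could remain at the limit. The expected change is an at least 2.0-fold lower number from compound 2 to compound 4 (0.30 log units; that floor lies within the scatter). For compound 4 the estimated value is 50000 nM, with an expected range of 12000 nM to 200000 nM.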

Compound 4, concentration for 50% growth inhibition: 5500 nM
For compound 4 the middle estimate is 9.1-fold (0.96 log units) above the measured one, and the stated range ends above it.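

In this assay, chloro in place of hydrogen on the aromatic carbon between two ring nitrogen atoms gives an at least 18-fold lower number from compound 2 to compound 4 (1.25 log units; beyond the scatter). Going by these compounds alone, this is the first readable step, as the earlier step between the two compounds at the limit could not be read. Compound 2 stands at a limit, so this step gives a floor on the size of the change and not its full size: the limit of > 100000 nM in this assay, at which 2 of the 4 values shown sit. With that chloro in place in both compounds, chloro in place of (4-methoxyphenyl)(methyl)amino on another aromatic carbon gives a 1.3-fold lower number from compound 1 to compound 4 (0.12 log units; within the scatter), so here the (4-methoxyphenyl)(methyl)amino group is not needed to reach this level of growth inhibition.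

The compounds shown leave open whether the effect belongs to chloro itself, or whether a fluoro, an amino group or a methoxy on the carbon between two ring nitrogen atoms would do the same. They also leave open whether the same chloro would carry over to compound 3, which has one more methoxy on its benzene ring than compound 2.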